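A Carboxymethyl Ester in Place of a tert-Butyl Ester

The source may hold more compounds than are shown below. What is called first, only, known or untested is meant among the compounds shown, and "the series" means these compounds.

Compound 1, `CCOC(=O)C(=O)Nc1cccccc1=O`: 91%
Compound 2, `CCOC(=O)C(=O)Nc1ccc(Cl)ccc1=O`: 25%
Compound 3, `CC(C)(C)OC(=O)C(=O)Nc1cccccc1=O`: 82%

These three compounds were measured in a functional assay on the whole organism (strain Sprague-Dawley CD) for inhibition, with Rattus norvegicus as the target, read by paw edema, at a dose of 100 mg/kg by the oral route; on this read-out higher numbers stand for a stronger effect at the one dose given and lower numbers for a weaker effect. Compound 3 stands second highest of the three numbers: its nearest neighbour is compound 1, separated by a number 9 percentage points lower from compound 1 to compound 3 (within the scatter), while compound 2 lies far below it, beyond the scatter.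

Compound 4, `O=C(O)COC(=O)C(=O)Nc1cccccc1=O`, has not yet been measured. It differs from compound 3 in one place: carboxymethyl in place of tert-butyl on an oxygen next to a carbonyl group. For the measured compounds named here, only one measured step touches the same place, the oxygen next to a carbonyl group, and that step was small. The other step, a number 66 percentage points lower from compound 1 to compound 2 (beyond the scatter), concerns an aromatic carbon and says nothing about the ester. Going by the values given here, no measured compound carries a carboxymethyl group or any hydrogen-bond donor at that oxygen, so the record is thin. The expected step is therefore a modest one, a number 12 percentage points lower from compound 3 to compound 4 (beyond the scatter), with wide uncertainty. Compound 4 is estimated to give 70%, within 35% to 92%.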

Compound 4, a percentage reported as inhibition, in the whole organism at one dose (the size of the read-out at that dose, not a potency): 50%
Compound 4: the middle estimate sits 20 percentage points above what was measured; measured number inside the range.
By their numbers in this assay, from the lowest: compound 2; then compound 4; then compounds 3 and 1 (each within the scatter of the next).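

At the oxygen next to a carbonyl group, the choice of group can matter a great deal in this assay: carboxymethyl in place of tert-butyl gives a number 32 percentage points lower from compound 3 to compound 4 (beyond the scatter). Carboxy in place of methyl on the saturated chain carbon gives a number 41 percentage points lower from compound 1 to compound 4 (beyond the scatter), so a change at the far end of the ester group is enough to move this number, even though ethyl and tert-butyl stay within the scatter of each other. No measurement shown accounts for this loss.

Still open, from the compounds shown here alone, is whether the loss belongs to the free carboxy group or to any oxygen-bearing chain, a question that a methyl ester of that carboxy group or a hydroxyethyl chain could help settle. Also open, going by these compounds, is how carboxymethyl at this oxygen would behave alongside chloro on the aromatic carbon.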